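Amide nitrogen variation in the dimethoxy series: ring closure

A few compounds are considered here, and "the series" means these few. Any claim that something is new, unique, unknown or untested is made for them only; others in the source may bear on it.

Compound 3 `COc1cc2c(cc1OC)C(CC(=O)NC1CCCC1)CC2` stands second highest of the three numbers measured in a functional assay on the whole organism (strain Swiss albino) for inhibition, with Mus musculus as the target, in the writhing test, with stated times of 60 min and 15 min, at a dose of 100 mg/kg by the oral route; on this read-out lower numbers stand for less inhibition and higher numbers for more inhibition at the one dose given (going by the name of the read-out); compound 3 gives 37%. Its nearest neighbour is compound 1 `COc1cc2c(cc1OC)C(CC(N)=O)CC2`, which gives 24.6%, and the furthest is compound 2 `CCCCCCNC(=O)CC1CCc2cc(OC)c(OC)cc21`, which gives 82.2%. The measured steps are a number 57.6 percentage points higher from compound 1 to compound 2 (beyond the scatter) for hexyl in place of hydrogen on the amide-type nitrogen, a number 12.4 percentage points higher from compound 1 to compound 3 (beyond the scatter) for cyclopentyl in place of hydrogen, and a number 45.2 percentage points lower from compound 2 to compound 3 (beyond the scatter) for cyclopentyl in place of hexyl.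

Compound 4 `COc1cc2c(cc1OC)C(CC(=O)N1CCCCC1)CC2` differs from compound 3 by piperidin-1-yl in place of cyclopentylamino on a carbonyl carbon. Among the compounds with values here, no measured step bears on this change directly: every measured step alters what the amide-type nitrogen carries while keeping its hydrogen, whereas here the nitrogen becomes part of the ring and the atom count stays the same. The measured steps show that the group on the nitrogen moves the read-out by large amounts, so a step in either direction cannot be excluded, but with the same atoms rearranged a step beyond the scatter is not expected. The expected step is a number 2 percentage points lower from compound 3 to compound 4 (within the scatter). Compound 4 is estimated at 35%, with a range from 15% to 58%.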

Compound 4, a percentage reported as inhibition, in the whole organism at one dose (the size of the read-out at that dose, not a potency): 44.7%
Beside the measured number, compound 4's estimate is 9.7 percentage points below it; the range from low to high includes it.
By their numbers in this assay, from the lowest: compound 1; then compounds 3 and 4 (each within the scatter of the next); then compound 2.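

In this assay, closing the nitrogen into the ring of piperidin-1-yl removes the amide hydrogen, yet the step is a number 7.7 percentage points higher from compound 3 to compound 4 (within the scatter) and so gives no sign that the amide hydrogen matters on this carbonyl carbon when the group carries this same set of atoms. The two ring-bearing groups also stand in a similar relation to the ends of the series: the tertiary amide shows a number 20.1 percentage points higher from compound 1 to compound 4 (beyond the scatter) and a number 37.5 percentage points lower from compound 2 to compound 4 (beyond the scatter), which places piperidin-1-yl, like cyclopentylamino, well short of hexylamino while still clear of the plain amino group. Within these four compounds, then, the large gain is seen only with the open hexyl chain, and compound 3 and compound 4 do not separate from one another; no measurement at hand accounts for these steps.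

Still open, on these data alone, is whether the high number belongs to hexyl specifically, which a butyl or octyl chain on the nitrogen would test. A methyl group added to the nitrogen of the hexyl amide would show whether loss of the amide hydrogen costs anything with an open chain, and morpholin-4-yl would extend the ring comparison.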